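The source may report more compounds than this note shows. Statements on the series, on what has been measured and on what is new or still open speak of the compounds shown alone.

The series is built around a shared core carrying two aryl groups on a piperidine whose nitrogen bears a three-carbon chain ending in an aryl ether. Among the compounds with values here, compound 1 `COc1ccc(C(c2ccc(OC)cc2)C2CCN(CCCOc3ccc(C(C)=O)cc3OC)CC2)cc1` and compound 3 `COc1cc(C(C)O)ccc1OCCCN1CCC(C(c2ccc(F)cc2)c2ccc(F)cc2)CC1` are the weakest of the three measured members in a functional assay (aorta) with Oryctolagus cuniculus as the target; on this read-out lower numbers stand for tighter binding and higher numbers for weaker binding: compound 1 gives 10 nM and compound 3 gives 10 nM, which are level at the digits recorded and within the usual scatter of each other. Compound 2 `COc1cc(C(C)=O)ccc1OCCCN1CCC(CC(c2ccc(F)cc2)c2ccc(F)cc2)CC1`, the other measured member, gives 3.16 nM in this assay, a lower number than compound 3 and beyond the scatter.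

Compound 4 `CC(C)(C)c1ccc(OCCCN2CCC(C(c3ccc(F)cc3)c3ccc(F)cc3)CC2)cc1` has not been measured. Compared with compound 3, the change is 4-(tert-butyl)phenyl in place of 4-(1-hydroxyethyl)-2-methoxyphenyl on an oxygen on a saturated carbon. Nothing among the three measured compounds shows the effect of exchanging the aryl ether end in this way, since all three keep the same 2-methoxyphenoxy pattern and differ elsewhere.

Within the data shown here, with no comparable step to lean on, the step from compound 3 to compound 4 is expected to be modest, near the edge of the scatter, with a slight lean toward a weaker number, giving a 1.6-fold higher number from compound 3 to compound 4 (0.20 log units; within the scatter). Compound 4 is therefore estimated at 16 nM in this assay, within a range from 4 nM to 63 nM.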

Compound 4, dissociation constant: 1 nM
Compound 4: the middle estimate sits 16-fold (1.20 log units) above what was measured, and the stated range ends above it.
By their numbers in this assay, from the lowest: compound 4; then compound 2; then compounds 1 and 3 (each within the scatter of the next).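

In this assay, the aryl ether end of the chain turns out to be a place where a single exchange moves the number well beyond the scatter: 4-(tert-butyl)phenyl in place of 4-(1-hydroxyethyl)-2-methoxyphenyl on an oxygen on a saturated carbon gives a 10-fold lower number from compound 3 to compound 4 (1.00 log units; beyond the scatter). Within the data shown here, this is the first one-place comparison, and it shows that neither the methoxy group nor the 1-hydroxyethyl group is required for a low number, as compound 4, whose entering group has no hydrogen-bond donors or acceptors, gives 1 nM. Nothing shown here accounts for the size of this step.

Going by these compounds, the exchange removes the methoxy and 1-hydroxyethyl groups and introduces the tert-butyl group all at once, so it remains open how much of the step belongs to each, and whether an isopropyl group, an amine or a carboxylic acid in place of the tert-butyl group would keep the low number. On these data alone, it also remains open whether 4-(tert-butyl)phenyl would give a similar step on the diaryl ends of compound 1 or compound 2, or with a longer chain on the oxygen.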